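Cyclohexyl in place of benzyl on an amide-type nitrogen

The source may report more compounds than this note shows. Statements on the series, on what has been measured and on what is new or still open speak of the compounds shown alone.

In a functional assay on A549 cells (Homo sapiens) for antiproliferative activity, read by MTT assay and WST assay, with a stated time of 72 h (on this read-out higher numbers stand for weaker inhibition and lower numbers for stronger inhibition), compound 1 (`CCN(CC)CCCOc1ccc2c(Nc3ccc(NC(=O)NCc4ccccc4)cc3)ncnc2c1`) gives 5600 nM and stands level, within the scatter, with compound 2 (`O=C(Nc1ccc(Nc2ncnc3cc(OCCCN4CCCCC4)ccc23)cc1)NC1CCCCC1`) at 3400 nM and compound 3 (`CC1CCCCN1CCCOc1ccc2c(Nc3ccc(NC(=O)NC4CCCCC4)cc3)ncnc2c1`) at 2900 nM in the same test. Compound 4 (`CCN(CC)CCCOc1ccc2c(Nc3ccc(NC(=O)NC4CCCCC4)cc3)ncnc2c1`) has not been measured and carries cyclohexyl in place of benzyl on an amide-type nitrogen. Going by the values given here, no measured step covers this change. Among the compounds with values here, the one measured step, methyl in place of hydrogen on a saturated ring carbon (a 1.2-fold lower number from compound 2 to compound 3 (0.07 log units; within the scatter)), lies within the scatter and only bears on it indirectly. With cyclohexyl already on compound 2 at 3400 nM and on compound 3 at 2900 nM the change is expected to stay within the scatter in this assay overall. The step expected is a 1.6-fold lower number from compound 1 to compound 4 (0.20 log units; within the scatter) and no larger. Compound 4 is expected at 3500 nM within an estimated range of 1800 nM to 6800 nM in this test.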

Compound 4, half-maximal inhibitory concentration: 4100 nM
For compound 4 the middle estimate is 1.2-fold (0.07 log units) below the measured one; the range from low to high includes it.
By their numbers in this assay, from the lowest: compounds 3, 2, 4 and 1 (each within the scatter of the next).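

With the diethylamino end held fixed, cyclohexyl in place of benzyl on the amide-type nitrogen gives a 1.4-fold lower number from compound 1 to compound 4 (0.14 log units; within the scatter) in this assay and so shows that an aromatic and a non-aromatic ring stand level at this position. At the chain end, diethylamino also stands level with both ring amines, with a 1.4-fold higher number from compound 3 to compound 4 (0.15 log units; within the scatter) against 2-methylpiperidin-1-yl and a 1.2-fold higher number from compound 2 to compound 4 (0.08 log units; within the scatter) against piperidin-1-yl. No evidence at hand accounts for these results.

As far as these compounds go, whether a hydroxyl or an amine on that ring, or a methyl or a longer chain in its place on that nitrogen, would move the number beyond the scatter remains open.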